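This account rests on a few compounds, and the source may have more. Where it says the series, first, only, none or still open, it means among the compounds named here.

Values in a physicochemical assay for solubility, at pH 7.4 (a lower number here means a less soluble compound, a higher number a more soluble compound), so far
compound 1 `CNC1(C)CN(c2c(F)cc3c(=O)c(C(=O)O)cn(C4CC4)c3c2F)C1` gives 0.5 ug/mL
compound 2 `C[C@H]1[C@H](N)CN1c1c(F)cc2c(=O)c(C(=O)O)cn(-c3ccc(F)cc3)c2c1F` gives 11.2 ug/mL
compound 3 `C[C@@H]1[C@@H](N(C)C)CN1c1cc2c(cc1F)c(=O)c(C(=O)O)cn2C1CC1` gives 96.3 ug/mL

Compound 1 holds the lowest of the three numbers, and the gaps up to compound 2 and compound 3 both lie beyond the scatter. Compound 4 `CN[C@H]1CN(c2c(F)cc3c(=O)c(C(=O)O)cn(C4CC4)c3c2F)[C@@H]1C` keeps the core of compound 1 and changes only the group on the aromatic carbon: a group of 7 heavy atoms (5 carbon, 2 nitrogen; one four-membered non-aromatic ring with 1 hetero atom) in place of a group of 7 heavy atoms (5 carbon, 2 nitrogen; one four-membered non-aromatic ring with 1 hetero atom), on an aromatic carbon is the whole difference, with the same atoms joined differently. Going by the values given here, no measured pair differs in one place, so no direct step exists to size this change. Compound 2 at 11.2 ug/mL and compound 3 at 96.3 ug/mL each differ from compound 1 in more than one place and offer only a loose guide. Both values point upward, so a rise in this assay is the expected direction, of moderate size and not certain to clear the scatter. The expected move is an 8.0-fold higher number from compound 1 to compound 4 (0.90 log units; beyond the scatter) as estimated here. Compound 4 is estimated at 4 ug/mL with an expected range from 0.8 ug/mL to 25 ug/mL for now.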

Compound 4, solubility: 13.1 ug/mL
Compound 4: the middle estimate sits 3.3-fold (0.52 log units) below what was measured; measured number inside the range.
By their numbers in this assay, from the lowest: compound 1; then compounds 2 and 4 (each within the scatter of the next); then compound 3.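

In this assay, going by these compounds alone, exchanging the 3-methyl-3-(methylamino)azetidin-1-yl group for its isomer on the same aromatic carbon gives a 26-fold higher number from compound 1 to compound 4 (1.42 log units; beyond the scatter), the first one-place step and a large one. The leaving and entering groups have the same heavy-atom, hydrogen-bond donor and acceptor counts and no net charge, so the number at this position can move well beyond the scatter with no change in those counts, only in how the same atoms are joined, and the entering group has 2 defined stereocentres. No measurement shown accounts for the size of this step.

The compounds shown do not separate the new connectivity from the stereochemistry of the entering group. Going by these compounds, how a hydroxyl group in place of the methylamino group would read on this core also remains open.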